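A few compounds are considered here, and "the series" means these few. Any claim that something is new, unique, unknown or untested is made for them only; others in the source may bear on it.

Of the compounds shown here, two have so far been measured in a functional assay on CHO-K1 cells for antagonist activity at adenosine receptor A1 (Homo sapiens), read by a beta-galactosidase reporter and cAMP accumulation, with stated times of 15 min and 6 h; on this read-out higher numbers stand for weaker inhibition and lower numbers for stronger inhibition. Compound 1 `Cc1ccc(-c2nc(N)c3ccsc3n2)o1` gives 493 nM in this assay. Compound 2 `Nc1nc(C2CCCO2)nc2sc(Cc3ccccc3)cc12` gives 2950 nM in this assay, the higher of the two numbers, and its gap to compound 1 lies beyond the usual scatter, so compound 2 is the weaker inhibitor of the pair.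

Compound 3 `N#Cc1cccc(-c2nc(N)c3cc(Cc4ccccc4)sc3n2)n1` has not yet been measured. It differs from compound 2 in a single place: 6-cyanopyridin-2-yl in place of oxolan-2-yl on an aromatic carbon. Among the compounds with values here, no measured pair shows this particular exchange, so its effect cannot be read from a completed step. What can be said is that compound 1, which carries an aromatic group at the same position of the shared core, gives the lower number with 493 nM, whereas compound 2, with a non-aromatic ring there, gives 2950 nM. On that basis the aromatic 6-cyanopyridin-2-yl group is expected to bring the number down, and the step of a 5.9-fold lower number from compound 2 to compound 3 (0.77 log units; beyond the scatter) is expected to be beyond the scatter in the direction of stronger inhibition. Compound 3 is therefore estimated at 500 nM, within a range from 100 nM to 2500 nM.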

Compound 3, inhibition constant: > 1000 nM
Compound 3 ended at the assay's limit; the forecaster's own chance of this, stated with the estimate: 5%; middle value at least 2.0-fold (0.30 log units) away from the limit.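

In this assay compound 3 gives > 1000 nM, which is a limit of the assay and not a number. The step from compound 2 to compound 3 therefore cannot be read, because compound 3 sits at that limit: the limit of > 1000 nM in this assay, at which 1 of the 3 values shown sits. The compounds shown leave open whether 6-cyanopyridin-2-yl in place of oxolan-2-yl strengthens or weakens inhibition, and by how much.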